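Chloro to Amino on the Fused Core of an Aminoindazole Urea

The source may report more compounds than this note shows. Statements on the series, on what has been measured and on what is new or still open speak of the compounds shown alone.

Measured compounds:
Compound 1, `Nc1nn(C(=O)Nc2ccc(Cc3ccccc3)cc2)c2ccccc12`, in a functional assay on M14 cells (Homo sapiens) for antiproliferative activity, read by sulforhodamine B assay, with a stated time of 48 h (on this read-out lower numbers stand for stronger inhibition of growth and higher numbers for weaker inhibition of growth), gives > 100000 nM.
Compound 2, `Nc1nn(C(=O)Nc2ccc(Cc3ccccc3)cc2)c2ccc(Cl)cc12`, in this assay gives 14000 nM.

Among the compounds with values here, compound 2 holds the only number in this assay. For compound 1 the assay returned only a limit, (the limit of > 100000 nM in this assay, at which 1 of the 2 values shown sits). Within the data shown here, the single measured step, an at least 7.1-fold lower number from compound 1 to compound 2 (0.85 log units; beyond the scatter), shows that placing chloro on the fused core brought the number from the limit down into the measurable range, with the step's true size unknown.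

Compound 3, `Nc1ccc2c(c1)c(N)nn2C(=O)Nc1ccc(Cc2ccccc2)cc1`, carries the change (amino in place of chloro on an aromatic carbon). Among the measured compounds shown here, the one measured step bears on it only through the chloro that now leaves; the amino that enters appears in no measured compound, so its effect is untested. Since chloro was what separated compound 2 from the limit shown by compound 1, its removal is expected to push the number upward, an estimated step of a 4.3-fold higher number from compound 2 to compound 3 (0.63 log units; beyond the scatter), with a real chance of returning only a limit. For compound 3 the estimated value is 60000 nM, within a range of 15000 nM to 150000 nM.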

Compound 3, concentration for total growth inhibition: 17800 nM
Beside the measured number, compound 3's estimate is 3.4-fold (0.53 log units) above it; the measured number falls inside the stated range.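

In this assay, amino and chloro on this aromatic carbon of the shared core cannot be told apart: the exchange gives a 1.3-fold higher number from compound 2 to compound 3 (0.10 log units; within the scatter), even though amino brings a hydrogen-bond donor and a hydrogen-bond acceptor that chloro lacks. Set against hydrogen at the same carbon, amino gives an at least 5.6-fold lower number from compound 1 to compound 3 (0.74 log units; beyond the scatter), so among these compounds a measurable number is no longer tied to chloro alone. Compound 1 gives a limit and not a number, and the true size of that step therefore stays unknown: the limit of > 100000 nM in this assay, at which 1 of the 3 values shown sits.

The three compounds leave open whether any group other than hydrogen on this carbon would give a measurable number, or whether something shared by chloro and amino matters; a methyl, a hydroxyl or a carboxylic acid at the same carbon would speak to that. They also leave open whether amino and chloro would still match on another carbon of this six-membered ring, or with a different group on the far side of the urea.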